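The compounds below may be only part of what the source reports. "The series", "measured", "known", "first", "only" and "open" are said of these compounds alone.

Measured so far in a functional assay on MCF7 cells (Homo sapiens) for antiproliferative activity, read by MTT assay, with a stated time of 48 h; on this read-out higher numbers stand for weaker inhibition and lower numbers for stronger inhibition:
- compound 1 `CCN(CC)Cc1ccc2c(c1O)-c1ccc(cc1O)CCc1ccc(O)c(c1)Oc1ccc(cc1)CC2`: 7590 nM
- compound 2 `Oc1ccc2cc1Oc1ccc(cc1)CCc1ccc(CN3CCCC3)c(O)c1-c1ccc(cc1O)CC2`: 2410 nM

Within the data shown here, of these two, compound 2 has the lower number, and compound 1 is its only comparison. Compound 3 `Oc1ccc2cc1Oc1ccc(cc1)CCc1ccc(CN3CCCCC3)c(O)c1-c1ccc(cc1O)CC2` has not yet been measured. It differs from compound 2 as follows: piperidin-1-yl in place of pyrrolidin-1-yl on a saturated chain carbon bound to an aromatic carbon. In short, piperidin-1-yl stands in place of pyrrolidin-1-yl on a saturated chain carbon bound to an aromatic carbon.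

Among the measured compounds shown here, one measured step bears on this change at the same place: a 3.1-fold lower number from compound 1 to compound 2 (0.50 log units; beyond the scatter). That step was modest, and it did not involve piperidin-1-yl, so it gives no firm direction. No step beyond the scatter is therefore expected in this assay. The expected change is a 1.2-fold higher number from compound 2 to compound 3 (0.07 log units; within the scatter). Compound 3 is estimated at 2800 nM, with an expected range from 1100 nM to 6500 nM.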

Compound 3, half-maximal inhibitory concentration: 5070 nM
The estimate for compound 3 lay 1.8-fold (0.26 log units) below the measured number; low and high end bracket the measured number.
By their numbers in this assay, from the lowest: compound 2; then compounds 3 and 1 (each within the scatter of the next).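

In this assay, the size of the amine ring at this place proves to matter: the change from pyrrolidin-1-yl to piperidin-1-yl gives a 2.1-fold higher number from compound 2 to compound 3 (0.32 log units; beyond the scatter) and so reverses the modest advantage that the five-membered ring held over the open diethylamino group. Piperidin-1-yl set against diethylamino gives a 1.5-fold lower number from compound 1 to compound 3 (0.18 log units; within the scatter) and thus no clear separation, which leaves compound 2 alone with the lowest number of the three. Nothing measured here accounts for why the five-membered ring stands apart from the other two amines.

On these data alone, whether a still smaller azetidin-1-yl ring would continue this trend, or a morpholin-4-yl ring with its added ring oxygen would keep the number of compound 2, stays open. As far as these compounds go, it is also open whether a dimethylamino group would stand with the diethylamino group of compound 1.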